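This account rests on a few compounds, and the source may have more. Where it says the series, first, only, none or still open, it means among the compounds named here.

Of the compounds shown here, two sharing one core have been measured in a functional assay on the whole organism (strain Sprague-Dawley) for inhibition, with Rattus norvegicus as the target, read by paw edema, with stated times of 1 h and 3 h, at a dose of 50 mg/kg by the oral route; a lower number here means less inhibition, a higher number more inhibition at the dose given (going by the name of the read-out). Compound 1, `Cc1ccc2ncc(C(=O)c3sc(N)nc3C)n2c1`, gives 33% in this assay. Compound 2, `Nc1ncc(C(=O)c2cnc3ccccn23)s1`, gives 33% in this assay. Compound 2 thus stands level with compound 1 at the digits shown; the gap lies within the usual scatter of repeated measurements, so neither number can be called the higher. Compound 3, `Cc1ccc2ncc(C(=O)c3cnc(N)s3)n2c1`, has not yet been measured in this assay. Compared with compound 2, the change is methyl in place of hydrogen on an aromatic carbon. Within the data shown here, no pair of measured compounds isolates this change, so there is no measured step to lean on. The two measured values lie within the scatter of each other, which gives no sign that a single small change shifts the read-out. The step of no change at the digits printed from compound 2 to compound 3 (within the scatter) is expected to stay within the scatter, in no clear direction. Compound 3 is therefore estimated at 33%, with a range from 15% to 50%.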

Compound 3, a percentage reported as inhibition, in the whole organism at one dose (the size of the read-out at that dose, not a potency): 53%
Estimate against measurement, compound 3: 20 percentage points below; measured number outside the range, above it.
By their numbers in this assay, from the lowest: compounds 1 and 2 (each within the scatter of the next); then compound 3.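

In this assay, methyl in place of hydrogen on an aromatic carbon of the six-membered ring, two atoms from the ring nitrogen, gives a number 20 percentage points higher from compound 2 to compound 3 (beyond the scatter), the first measured sign that one small change at this position can move the read-out. The second single change, hydrogen in place of methyl on an aromatic carbon, gives a number 20 percentage points higher from compound 1 to compound 3 (beyond the scatter), so compound 3 holds the highest number of the three. Nothing measured here bears on why either step occurs.

On these data alone, whether an ethyl group, a methoxy group or a chlorine atom at the same position would raise, hold or lower the number remains open. These numbers also come from a single dose, so they leave open how the compounds would compare across other doses.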